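Adding a carboxy group to the phenyl of compound 3

The source may hold more compounds than are shown below. What is called first, only, known or untested is meant among the compounds shown, and "the series" means these compounds.

Measured compounds in an ADME assay on S9 fraction from liver (Rattus norvegicus) for metabolic stability, read by LC-MS, using NADPH, with a stated time of 30 min; a higher number here means that more of the compound is left, a lower number that less of the compound is left:
Compound 1, `CCCCCCCCc1ccc(OCC(=O)Cn2nnc(-c3ccccc3)n2)cc1`: 33%
Compound 2, `CCCCCCCCc1ccc(OCC(=O)Cn2nnc(C(=O)OC)n2)cc1`: compound 2 reaches only the assay's limit, < 5%
Compound 3, `CCCCCCCCc1ccc(OCC(=O)Cn2nnnc2-c2ccccc2)cc1`: 36%

Compound 3 holds the highest of the two actual numbers, with compound 1 close by and within the scatter, while compound 2 is reported only as a limit (the limit of < 5% in this assay, at which 1 of the 3 values shown sits). The unmeasured compound 4, `CCCCCCCCc1ccc(OCC(=O)Cn2nnnc2-c2ccc(C(=O)O)cc2)cc1`, differs from compound 3 by carboxy in place of hydrogen on an aromatic carbon. Among the measured compounds shown here, only one measured step exists, a number at least 28 percentage points lower from compound 1 to compound 2 (beyond the scatter), and it concerns a different change: there the phenyl itself was replaced, whereas here the phenyl stays and a carboxy is added on it. For the measured compounds named here, no measured step adds a carboxy, so that step bears on the present change only loosely. The expectation is therefore a step of a number 4 percentage points higher from compound 3 to compound 4 (within the scatter) in this assay, in either direction and not clearly beyond the scatter. Compound 4 is estimated at 40%, within 20% to 65%.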

Compound 4, percent of the compound remaining: 6%
The estimate for compound 4 lay 34 percentage points above the measured number; the whole stated range lies above it.
By their numbers in this assay, from the lowest: compound 4; then compounds 1 and 3 (each within the scatter of the next). At a limit, below all of these: compound 2.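

In this assay the phenyl of compound 3 does not tolerate every addition: carboxy in place of hydrogen on an aromatic carbon, para to a large group, gives a number 30 percentage points lower from compound 3 to compound 4 (beyond the scatter) and so marks this position as one where a small added group can matter. The earlier step at a phenyl replaced the whole ring substituent, whereas here the phenyl stays and the addition of carboxy alone is enough for a step beyond the scatter. Nothing measured among these compounds explains why the number falls with this change.

Open, going by these compounds, is whether an amine or a hydroxy group at the same place would give a similar number or one nearer that of compound 3. Also open, on these data alone, is whether the same carboxy on the phenyl of compound 1 would give a step of similar size.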